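Swapping methylamino for ethyl on compound 3

The compounds below may be only part of what the source reports. "The series", "measured", "known", "first", "only" and "open" are said of these compounds alone.

Of the compounds shown here, three sharing one core have been tested in a toxicity assay on NIH3T3 cells (Mus musculus) for cytotoxicity, read by resazurin assay (on this read-out lower numbers stand for an effect already at smaller amounts and higher numbers for an effect only at larger amounts of compound), so far. Compound 1 (`CN(C)c1ccc(NCc2cncn2Cc2ccc(-c3ccccc3)cc2)cc1-c1ccccc1`) gives > 1000 nM there, which is a limit of the assay. Compound 3 (`CNC(=O)c1ccc(NCc2cncn2Cc2ccc(-c3ccccc3)cc2)cc1-c1ccccc1`) gives > 1000 nM, which is also a limit. Going by the values given here, compound 3 therefore has no number of its own, and its place is the limit of > 1000 nM in this assay, at which 2 of the 3 values shown sit, as the only guide. Among the compounds with values here, compound 2 (`c1ccc(-c2ccc(Cn3cncc3CNc3cccc(-c4ccccc4)c3)cc2)cc1`) reads 10000 nM as the only true number.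

Compound 4 (`CCC(=O)c1ccc(NCc2cncn2Cc2ccc(-c3ccccc3)cc2)cc1-c1ccccc1`) differs from compound 3 as follows: ethyl in place of methylamino on a carbonyl carbon. Methylcarbamoyl thus becomes propanoyl. The measured steps involving methylcarbamoyl are a step that the two limits leave unreadable from compound 1 to compound 3 and a step that the limit leaves unreadable from compound 2 to compound 3, so neither gives a size to carry over. No direction can be read from them either. The estimate therefore rests on compound 2 at 10000 nM. The limits of compound 1 and compound 3 also enter into it. The expected change is a step that the limit leaves unreadable from compound 3 to compound 4, with no direction expected. Compound 4 is expected at 8000 nM in this assay, with an estimated range of 2000 nM to 30000 nM as its likely span.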

Compound 4, half-maximal effective concentration: > 10000 nM
Compound 4 was reported as a limit; the forecaster's own chance of this, stated with the estimate: 60%; middle value at least 1.2-fold (0.09 log units) away from the limit.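

In this assay, compound 4 gives > 10000 nM, which is a limit of the assay and not a number, and it stands alone at that limit: the limit of > 10000 nM in this assay, at which 1 of the 4 values shown sits.

Propanoyl in place of hydrogen on an aromatic carbon gives a number no lower from compound 2 to compound 4 (the limit leaves the size open), so this is the first readable direction for a group at this place on the shared core. The other two new steps, ethyl in place of methylamino and propanoyl in place of dimethylamino, cannot be read, since limits stand at both ends.

As far as these compounds go, the true numbers for compound 3 and compound 4 stay open, and so does any effect of swapping methylamino for ethyl. From the compounds shown here alone, how a carboxylic acid or a longer chain on this carbonyl carbon would read in this assay is also open.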